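The compounds below may be only part of what the source reports. "The series", "measured", "known", "first", "only" and "open" are said of these compounds alone.

Measured so far in a functional assay on A549 cells (Homo sapiens) for antiproliferative activity, read by MTT assay, with a stated time of 72 h; on this read-out lower numbers stand for stronger inhibition and higher numbers for weaker inhibition:
- compound 1 `COc1cc(F)c(NC(=O)c2ncccn2)cc1Nc1nccc(-c2cn(C)c3ccccc23)n1`: 8400 nM
- compound 2 `COc1cc(N(C)C)c(NC(=O)c2ccncc2OC)cc1Nc1nccc(-c2cn(C)c3ccccc23)n1`: 3030 nM
- compound 3 `COc1ccc(C(=O)Nc2cc(Nc3nccc(-c4cn(C)c5ccccc45)n3)c(OC)cc2N(C)C)nc1`: 5150 nM

Within this small set, compound 3 sits second highest of the three numbers. Its nearest neighbour is compound 1, whose number is somewhat higher, and its furthest is compound 2, whose number is somewhat lower; both of these gaps fall inside the usual scatter, so no order among the three can be claimed.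

Compound 4 `COc1cc(N(C)C)c(NC(=O)c2ncccn2)cc1Nc1nccc(-c2cn(C)c3ccccc23)n1` has not yet been measured. It differs from compound 3 in one place: pyrimidin-2-yl in place of 5-methoxypyridin-2-yl on a carbonyl carbon. Among the measured compounds shown here, only one measured step bears on a change at this position, namely a 1.7-fold higher number from compound 2 to compound 3 (0.23 log units; within the scatter), which exchanged one six-membered aromatic ring for another on the same carbonyl carbon without moving the number beyond the scatter. Compound 1 also carries pyrimidin-2-yl on that carbonyl, but it differs from compound 4 in a second place as well, so its value and that of compound 3 can only be set side by side, not read as a step.

On this basis the step of a 1.1-fold higher number from compound 3 to compound 4 (0.03 log units; within the scatter) is expected to stay within the scatter. Compound 4 is therefore estimated at 5500 nM, with a range from 2000 nM to 15000 nM.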

Compound 4, half-maximal inhibitory concentration: 8640 nM
The estimate for compound 4 lay 1.6-fold (0.20 log units) below the measured number, and the stated range covers the measured number.
By their numbers in this assay, from the lowest: compounds 2, 3, 1 and 4 (each within the scatter of the next, the first and the last beyond it).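

In this assay, among the compounds shown here, the position on the carbonyl carbon now gives a step beyond the scatter, which no earlier pair showed: pyrimidin-2-yl in place of 3-methoxypyridin-4-yl gives a modest shift (a 2.9-fold higher number from compound 2 to compound 4 (0.46 log units; beyond the scatter)), whereas pyrimidin-2-yl in place of 5-methoxypyridin-2-yl does not clear the scatter (a 1.7-fold higher number from compound 3 to compound 4 (0.22 log units; within the scatter)). The new compound also allows a reading at a second place, on an aromatic carbon, where dimethylamino in place of fluoro, with pyrimidin-2-yl on the carbonyl in both compounds, leaves the number within the scatter (a 1.0-fold higher number from compound 1 to compound 4 (0.01 log units; within the scatter)). No measurement at hand offers an explanation for any of these steps.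

All the groups shown on the carbonyl carbon are six-membered aromatic rings, so it remains open how this position would respond to a saturated ring such as piperidine, to a longer alkyl chain or to a carboxylic acid. As far as these compounds go, it is equally open whether the exchange on the aromatic carbon would stay within the scatter with a larger amine such as morpholine, or with one of the methoxypyridinyl groups on the carbonyl.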